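This account rests on a few compounds, and the source may have more. Where it says the series, first, only, none or still open, it means among the compounds named here.

Compound 1 `COc1ccc(NC(=O)Nc2ccc(Nc3ncnc4c3OCCN4)cc2)cc1` gives 1220 nM in an assay on isolated protein for inhibition of proto-oncogene tyrosine-protein kinase receptor Ret variant V804L (Homo sapiens), read by 33P incorporation, with stated times of 15 min and 40 min; on this read-out higher numbers stand for weaker inhibition and lower numbers for stronger inhibition. Compound 2 `O=C(Nc1ccc(Nc2ncnc3c2OCCN3)cc1)Nc1cccs1` gives > 10000 nM in this assay, which is a limit of the assay rather than a number.

Compound 2 therefore stands at the weak end of the two measurements, beyond the reach of a number. For the measured compounds named here, the only measured step, an at least 8.1-fold higher number from compound 1 to compound 2 (0.91 log units; beyond the scatter), concerns a different swap and bears on the next change only loosely. Compound 3 `CC(C)(C)c1csc(NC(=O)Nc2ccc(Nc3ncnc4c3OCCN4)cc2)n1` differs from compound 2 by 4-(tert-butyl)-1,3-thiazol-2-yl in place of thiophen-2-yl on an amide-type nitrogen. With compound 2 sitting at the limit of > 10000 nM in this assay, at which 1 of the 2 values shown sits, the step of an at least 2.0-fold lower number from compound 2 to compound 3 (0.30 log units; that floor lies within the scatter) is expected to be small or towards stronger inhibition. Compound 3 is expected to give about 5000 nM in this assay, within 800 nM to 30000 nM.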

Compound 3, half-maximal inhibitory concentration: > 10000 nM
Compound 3: a limit, no number; the forecaster's own chance of this, stated with the estimate: 45%; middle value at least 2.0-fold (0.30 log units) away from the limit.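

Compound 3 ends at a limit of the assay, not at a number: the limit of > 10000 nM in this assay, at which 2 of the 3 values shown sit. The step between compound 2 and compound 3 therefore cannot be read, so adding tert-butyl and a ring nitrogen shows no visible gain or loss. Placing 4-(tert-butyl)-1,3-thiazol-2-yl on this amide-type nitrogen in place of 4-methoxyphenyl gives an at least 8.1-fold higher number from compound 1 to compound 3 (0.91 log units; beyond the scatter), so a second five-membered aromatic ring also stands behind 4-methoxyphenyl here.

From the compounds shown here alone, what remains open is whether an unsubstituted phenyl or a 4-chlorophenyl on this nitrogen would match compound 1 or surpass it.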